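Replacing the carboxy of compound 2 by ethyl

A few compounds are considered here, and "the series" means these few. Any claim that something is new, unique, unknown or untested is made for them only; others in the source may bear on it.

Compound 2 `Cn1ncc(Cl)c1-c1cc(C(=O)N[C@@H]2CN[C@H](CC(=O)O)C[C@H]2c2ccc(Cl)c(Cl)c2)oc1Cl` gives 5120 nM in a functional assay on OVCAR-8 cells (Homo sapiens) for antiproliferative activity (on this read-out lower numbers stand for stronger inhibition and higher numbers for weaker inhibition), the highest of the three numbers in the series. Compound 1 `Cn1ncc(Cl)c1-c1cc(C(=O)N[C@@H]2CN[C@H](CC(=O)NC3CC3)C[C@H]2c2ccc(Cl)c(Cl)c2)oc1Cl` gives 580 nM, and compound 3 `Cn1ncc(Cl)c1-c1cc(C(=O)N[C@@H]2CN[C@H](CC(N)=O)C[C@H]2c2ccc(Cl)c(Cl)c2)oc1Cl` gives 1000 nM. Compound 4 `CCC[C@@H]1C[C@@H](c2ccc(Cl)c(Cl)c2)[C@H](NC(=O)c2cc(-c3c(Cl)cnn3C)c(Cl)o2)CN1` differs from compound 2 by ethyl in place of carboxy on a saturated chain carbon bound to a saturated ring carbon: the carboxy with its hydrogen-bond donor and acceptor leaves, and ethyl enters on the saturated chain carbon bound to a saturated ring carbon. Among the compounds with values here, two steps bear on this, a 5.1-fold lower number from compound 2 to compound 3 (0.71 log units; beyond the scatter) and an 8.8-fold higher number from compound 1 to compound 2 (0.95 log units; beyond the scatter), both showing that exchanging the carboxy lowers the number beyond the scatter. Every measured compound keeps a carbonyl on that chain carbon, so the size for a plain ethyl is uncertain. A modest step toward lower numbers is therefore expected, a 5.1-fold lower number from compound 2 to compound 4 (0.71 log units; beyond the scatter). Compound 4 is estimated at 1000 nM, within 300 nM to 3500 nM.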

Compound 4, half-maximal inhibitory concentration: 1620 nM
For compound 4 the middle estimate is 1.6-fold (0.21 log units) below the measured one; the range from low to high includes it.
By their numbers in this assay, from the lowest: compounds 1, 3 and 4 (each within the scatter of the next, the first and the last beyond it); then compound 2.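

In this assay a carbonyl on the saturated chain carbon bound to a saturated ring carbon is not needed to move away from the carboxy result: ethyl alone gives a 3.2-fold lower number from compound 2 to compound 4 (0.50 log units; beyond the scatter) with no amide in place. Against carbamoyl, ethyl gives a 1.6-fold higher number from compound 3 to compound 4 (0.21 log units; within the scatter) and against cyclopropylcarbamoyl it gives a 2.8-fold higher number from compound 1 to compound 4 (0.45 log units; beyond the scatter) so among the amides only cyclopropylcarbamoyl keeps a lower number than ethyl. As far as these compounds go, whether a butyl chain or an aminoethyl group on that carbon would track ethyl or cyclopropylcarbamoyl stays open. No measurement here gives a reason for these steps.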